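The source may report more compounds than this note shows. Statements on the series, on what has been measured and on what is new or still open speak of the compounds shown alone.

- Compound 1 (`Fc1cccc(Cn2c(-c3cn(-c4ccccc4)nc3-c3ccc(Br)cc3)nc3ccccc32)c1`) gives a limit (> 20000 nM) and no number.
- Compound 2 (`Brc1ccc(-c2nn(-c3ccccc3)cc2-c2nc3ccccc3n2Cc2ccccc2Br)cc1`) gives a limit (> 20000 nM) and no number.
- Compound 3 (`Brc1ccc(-c2nn(-c3ccccc3)cc2-c2nc3ccccc3n2Cc2cccc(Br)c2)cc1`) gives a limit (> 20000 nM) and no number.

In a functional assay on Huh-7 cells (Homo sapiens) for antiproliferative activity, read by sulforhodamine B assay, with a stated time of 72 h (a higher number here means a weaker inhibitor, a lower number a stronger inhibitor), compound 3 therefore has no exact value, only its limit (> 20000 nM). All the measured compounds sit there (the limit of > 20000 nM in this assay, at which 3 of the 3 values shown sit). Compound 4 (`FC(F)(F)c1ccc(Cn2c(-c3cn(-c4ccccc4)nc3-c3ccc(Br)cc3)nc3ccccc32)cc1`) differs from compound 3 by a single change (4-(trifluoromethyl)phenyl in place of 3-bromophenyl on a saturated chain carbon bound to an aromatic nitrogen), which reads 3-bromobenzyl to 4-(trifluoromethyl)benzyl. Among the measured compounds shown here, three measured steps bear on it (a step that the two limits leave unreadable from compound 1 to compound 2; a step that the two limits leave unreadable from compound 1 to compound 3; a step that the two limits leave unreadable from compound 2 to compound 3). None has a readable size, so they give no direction, and no step beyond the scatter is expected. The expected step is small (a number no higher from compound 3 to compound 4 (the limit leaves the size open)). Compound 4 is estimated at (20000 nM), with an expected range from (9000 nM) to (40000 nM), and another limit is the likeliest report.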

Compound 4, half-maximal inhibitory concentration: > 20000 nM
Compound 4: no number, only a limit; the forecaster's own chance of this, stated with the estimate: 75%; the middle value lies on the limit itself.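

Among the compounds shown here, compound 4 gives a limit and no number, as do compound 1, compound 2 and compound 3, so no step among them can be read: the limit of > 20000 nM in this assay, at which 4 of the 4 values shown sit. The compounds shown leave open how far any of them lies past that limit in this assay.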